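The compounds below may be only part of what the source reports. "The series", "measured", "known", "first", "only" and "open" are said of these compounds alone.

Working notes on the series. Compound 1 `CCCSc1nc(N/N=C/c2ccccc2F)c2nnn(Cc3ccccc3)c2n1` sits at the limit of the assay in a functional assay on MGC-803 cells (Homo sapiens) for antiproliferative activity, read by MTT assay, with a stated time of 72 h; a lower number here means a stronger inhibitor, a higher number a weaker inhibitor: compound 1 gives > 64000 nM, a limit and not a number. Compound 2 `CCCSc1nc(N/N=C/c2ccccc2Cl)c2nnn(Cc3ccccc3)c2n1` gives 10900 nM in this assay, and compound 3 `CCCSc1nc(N/N=C(\C)c2ccccc2O)c2nnn(Cc3ccccc3Cl)c2n1` gives 35000 nM. Among the measured compounds shown here, the only measured single-point step is an at least 5.8-fold lower number from compound 1 to compound 2 (0.76 log units; beyond the scatter), its size bounded by the limit of > 64000 nM in this assay, at which 1 of the 3 values shown sits. Among the two numbers shown, compound 2 gives the lowest, with compound 3 nearest at a higher number, a gap beyond the scatter.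

Compound 4 `CCCSc1nc(N/N=C/c2ccc(C)cc2)c2nnn(Cc3ccccc3)c2n1` is not yet measured. It differs from compound 2 as follows: 4-methylphenyl in place of 2-chlorophenyl on a carbon with a double bond to nitrogen. For the measured compounds named here, the measured step bears on it only loosely: it shows that exchanging a halogen on an aromatic carbon of the ring attached to the carbon with a double bond to nitrogen can move the number a long way, but no measured compound carries a 4-methylphenyl there and no measured step removes the chloro altogether. An expectation therefore rests more on the spread of the numbers shown than on a matching step. The change is expected to give a 2.0-fold higher number from compound 2 to compound 4 (0.30 log units; within the scatter) in this assay, toward a higher number. Compound 4 is expected to give about 22000 nM in this assay, between 6000 nM and 64000 nM.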

Compound 4, half-maximal inhibitory concentration: > 64000 nM
Compound 4 ended at the assay's limit (the forecaster's own chance of this, stated with the estimate: 25%); middle value at least 2.9-fold (0.46 log units) away from the limit.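

Putting 4-methylphenyl in place of 2-chlorophenyl on a carbon with a double bond to nitrogen gives an at least 5.8-fold higher number from compound 2 to compound 4 (0.76 log units; beyond the scatter) in this assay, so this position responds to more than the halogen exchange seen earlier. Of compound 1, compound 4 and compound 2, which differ only in this group, compound 2 alone gives a readable number, so neither 2-fluorophenyl nor 4-methylphenyl matches 2-chlorophenyl here; compound 3 differs in more than one place and does not enter this comparison. Compound 4 gives > 64000 nM, a limit and not a number, as compound 1 also does, so the step between these two cannot be read: the limit of > 64000 nM in this assay, at which 2 of the 4 values shown sit.

Whether the step from 2-chlorophenyl to 4-methylphenyl follows from the chloro leaving or the methyl entering stays open, since neither plain phenyl, 2-methylphenyl nor 4-chlorophenyl stands among the compounds shown. Also open, as far as these compounds go, is whether a bromo or an amine on this aromatic ring would give a number lower than that of compound 2.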